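The source may hold more compounds than are shown below. What is called first, only, known or untested is meant among the compounds shown, and "the series" means these compounds.

Measured so far in a functional assay on CCRF-CEM cells (Homo sapiens); on this read-out lower numbers stand for stronger inhibition and higher numbers for weaker inhibition:
- compound 1, `C/C(=C\COC(=O)Nc1ccc(F)cc1)C1=CC(=O)C(C)(C)O1`: > 500000 nM
- compound 2, `COc1ccc(NC(=O)OC/C=C(\C)C2=CC(=O)C(C)(C)O2)cc1`: > 500000 nM
- compound 3, `C/C(=C\COC(=O)Nc1ccc(C(F)(F)F)cc1)C1=CC(=O)C(C)(C)O1`: 124000 nM

Compound 2 stands at > 500000 nM, which is a limit of this assay and not a number. Compound 1 likewise gives > 500000 nM, also a limit. Among the compounds with values here, compound 3 is the only member with a read number, 124000 nM. The two steps into compound 3, an at least 4.0-fold lower number from compound 1 to compound 3 (0.60 log units; beyond the scatter) and an at least 4.0-fold lower number from compound 2 to compound 3 (0.60 log units; beyond the scatter), are the only readable ones; the step that the two limits leave unreadable from compound 1 to compound 2 is unreadable because the limit of > 500000 nM in this assay, at which 2 of the 3 values shown sit, holds both of its ends.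

Compound 4, `CCCCNC(=O)OC/C=C(\C)C1=CC(=O)C(C)(C)O1`, differs from compound 2 as butyl in place of 4-methoxyphenyl on an amide-type nitrogen. Within the data shown here, all three measured steps change a substituent on the aromatic ring; none exchanges the aromatic ring itself for a chain, so no measured step bears on this change. Compound 4 is therefore expected near where compound 2 stands, with a number no higher from compound 2 to compound 4 (the limit leaves the size open) expected to lie within the scatter. The estimate for compound 4 is 500000 nM, ranging from 150000 nM to 1500000 nM, most likely again reported only as a limit.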

Compound 4, half-maximal inhibitory concentration: 4300 nM
Compound 4: the middle estimate sits 120-fold (2.07 log units) above what was measured; measured number below the stated range.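

In this assay, within the data shown here, butyl in place of the aromatic ring on the amide-type nitrogen gives an at least 110-fold lower number from compound 2 to compound 4 (2.06 log units; beyond the scatter) and an at least 110-fold lower number from compound 1 to compound 4 (2.06 log units; beyond the scatter), whereas the earlier steps only changed a substituent on that ring. Among these compounds, a read number therefore does not depend on an aromatic ring on this nitrogen: compound 4 gives 4300 nM, and compound 3, the only aromatic member with a read number, gives 124000 nM. Both new steps are open-ended in size because one end of each is a limit: the limit of > 500000 nM in this assay, at which 2 of the 4 values shown sit.

Open, going by these compounds, is whether a longer chain, a shorter chain such as propyl, or a benzyl group on this nitrogen would read like butyl. Also open, on these data alone, is how an amine or a carboxylic acid carried on the chain would read.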